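The compounds below may be only part of what the source reports. "The series", "measured", "known", "first", "only" and "open" are said of these compounds alone.

Measured compounds:
Compound 1 `NC1CCN(c2ccc3cc(NC(=O)CCc4ccc(C(F)(F)F)cc4)ccc3n2)C1` – 200 nM
Compound 2 `O=C(CCc1ccc(C(F)(F)F)cc1)Nc1ccc2nc(N3CCC(c4ccccc4)C3)ccc2c1` – 1770 nM
Compound 3 `Nc1ccc2cc(NC(=O)CCc3ccc(C(F)(F)F)cc3)ccc2n1` – 720 nM

In a functional assay on HEK293 cells for activation of melanin-concentrating hormone receptor 1 (Rattus norvegicus), read by inositol phosphate accumulation (a higher number here means that more compound is needed for the effect, a lower number that less compound is needed), compound 3 stands second highest of the three numbers: its nearest neighbour is compound 2, a 2.5-fold lower number from compound 2 to compound 3 (0.39 log units; beyond the scatter), while its furthest is compound 1, a 3.6-fold higher number from compound 1 to compound 3 (0.56 log units; beyond the scatter).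

Compound 4 `O=C(CCc1ccc(C(F)(F)F)cc1)Nc1ccc2nc(N3CCC3)ccc2c1` differs from compound 3 in one place: azetidin-1-yl in place of amino on an aromatic carbon. The two steps that bear on this change are the ones leading into compound 3 from the other cyclic amines. Replacing 3-aminopyrrolidin-1-yl with amino gave a 3.6-fold higher number from compound 1 to compound 3 (0.56 log units; beyond the scatter), whereas replacing 3-phenylpyrrolidin-1-yl with amino gave a 2.5-fold lower number from compound 2 to compound 3 (0.39 log units; beyond the scatter). A cyclic amine in this place can therefore move the number in either direction, and the size of both steps was modest. Azetidin-1-yl carries neither the extra amino of compound 1 nor the phenyl of compound 2, so the expected step from compound 3 to compound 4 in this assay is a 1.2-fold lower number from compound 3 to compound 4 (0.08 log units; within the scatter), which is expected to stay within or close to the scatter, with a slight lean toward a lower number. Compound 4 is accordingly estimated at 600 nM in this assay, with a range from 200 nM to 1800 nM.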

Compound 4, half-maximal effective concentration: 56 nM
Estimate against measurement, compound 4: 11-fold (1.03 log units) above; measured number outside the range, below it.
By their numbers in this assay, from the lowest: compound 4; then compound 1; then compound 3; then compound 2.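

In this assay, among the compounds shown here, azetidin-1-yl on this aromatic carbon next to the ring nitrogen gives a large step (a 13-fold lower number from compound 3 to compound 4 (1.11 log units; beyond the scatter)), so a cyclic amine here can do far more than the modest steps among the earlier compounds suggested. The same group also stands well apart from both substituted five-membered rings, with a large step from the phenyl-bearing ring (a 32-fold lower number from compound 2 to compound 4 (1.50 log units; beyond the scatter)) and a modest one from the amino-bearing ring (a 3.6-fold lower number from compound 1 to compound 4 (0.55 log units; beyond the scatter)); compound 4 thus has the lowest number of the four, with all its steps beyond the scatter, and a larger group at this place does not simply give a lower number, as compound 2 shows. No measurement shown here accounts for the size of these steps.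

The compounds shown leave open whether the four-membered ring itself matters or whether simple alkyl groups on this nitrogen would serve as well, which a dimethylamino group would test. They also leave open how the number moves with ring size alone, since unsubstituted pyrrolidin-1-yl and piperidin-1-yl lie outside this set.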